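The source may report more compounds than this note shows. Statements on the series, on what has been measured and on what is new or still open speak of the compounds shown alone.

Compound 3, with the structure `COc1cc(N2C(N)=C(C#N)C(c3cccs3)C3=C2CC(C)(C)CC3=O)cc(OC)c1OC`, carries a trimethoxyphenyl-bearing core shared with compound 1, `COc1cc(N2C(N)=C(C#N)C(c3c(OC)ccc4ccccc34)C3=C2CC(C)(C)CC3=O)cc(OC)c1OC`, and compound 2, `COc1cc(N2C(N)=C(C#N)C(c3ccc(OC)c4ccccc34)C3=C2CC(C)(C)CC3=O)cc(OC)c1OC`. In a functional assay on Ehrlich cells (Mus musculus) for cytotoxicity, tested at 50 ug/mL (a lower number here means a weaker effect, a higher number a stronger effect of the compound at the concentration tested), compound 3 gives 15%, compound 1 gives 10%, and compound 2 gives 40%. On these numbers compound 3 stands second highest of the three: its nearest neighbour is compound 1, within the scatter, and its furthest is compound 2, beyond it.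

Compound 4, `COc1cc(N2C(N)=C(C#N)C(c3ccc(O)cc3)C3=C2CC(C)(C)CC3=O)cc(OC)c1OC`, is not yet measured. The change from compound 3 is 4-hydroxyphenyl in place of thiophen-2-yl on a saturated ring carbon. Among the compounds with values here, no measured step introduces a 4-hydroxyphenyl group, so only the steps at the same saturated ring carbon bear on it. There the step of a number 5 percentage points higher from compound 1 to compound 3 (within the scatter) lies within the scatter, while the step of a number 25 percentage points lower from compound 2 to compound 3 (beyond the scatter) is a modest one beyond it, so a group swapped at this position can move the read-out modestly in either direction, or not at all. In this assay compound 4 is therefore expected to give about 20%, with a range from 5% to 45%, which means an expected step of a number 5 percentage points higher from compound 3 to compound 4 (within the scatter) that is likely to remain within the scatter.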

Compound 4, a percentage reported as activity, at one concentration (the size of the read-out at that concentration, not a potency): 90%
Compound 4: the middle estimate sits 70 percentage points below what was measured; measured number above the stated range.
By their numbers in this assay, from the lowest: compounds 1 and 3 (each within the scatter of the next); then compound 2; then compound 4.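

In this assay, placing 4-hydroxyphenyl on the saturated ring carbon gives a number 75 percentage points higher from compound 3 to compound 4 (beyond the scatter) and, against the two methoxynaphthalene-bearing compounds, a number 50 percentage points higher from compound 2 to compound 4 (beyond the scatter) and a number 80 percentage points higher from compound 1 to compound 4 (beyond the scatter) as well. The earlier compounds had shown only modest steps at this carbon, whereas these three are all large and all upward, so this position can carry far more of the read-out than they suggested, and compound 4 stands above each of the other three beyond the scatter. Nothing available here accounts for the size of these steps.

The change from thiophen-2-yl replaces the ring and adds the hydroxyl in a single step, so the compounds shown leave open whether the rise follows the hydroxyl or the six-membered carbon ring; a plain phenyl, a 4-methoxyphenyl or a 4-aminophenyl at this carbon would separate the two. They also leave open how potent compound 4 is, as a read-out at one concentration gives the size of the effect at that concentration and not a potency.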